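Pyrrolidine for diethylamine on a second quinazoline core

The source may report more compounds than this note shows. Statements on the series, on what has been measured and on what is new or still open speak of the compounds shown alone.

Compound 1 `CCN(CC)C/C=C/C(=O)Nc1cc2c(N3CCc4ccccc43)ncnc2cc1OC` and compound 2 `COc1cc2ncnc(N3CCc4ccccc43)c2cc1NC(=O)/C=C/CN1CCCC1` share one core, and in a functional assay on PC-3 cells (Homo sapiens) for antiproliferative activity, read by MTT assay, with a stated time of 72 h (on this read-out lower numbers stand for stronger inhibition and higher numbers for weaker inhibition), compound 1 gives 3690 nM while compound 2 gives 2620 nM. The change between them is pyrrolidin-1-yl in place of diethylamino on a saturated chain carbon bound to a double-bonded chain carbon, and it made the step of a 1.4-fold lower number from compound 1 to compound 2 (0.15 log units; within the scatter). Compound 3 `CCN(CC)C/C=C/C(=O)Nc1cc2c(N3CCCc4ccccc43)ncnc2cc1O[C@@H]1CCOC1` carries a different core; how the two cores differ is not broken down here. In this assay compound 3 gives 4270 nM. Compound 4 `O=C(/C=C/CN1CCCC1)Nc1cc2c(N3CCCc4ccccc43)ncnc2cc1O[C@@H]1CCOC1` is obtained from compound 3 by the same change, (pyrrolidin-1-yl in place of diethylamino on a saturated chain carbon bound to a double-bonded chain carbon), at the same place. Because the earlier step of a 1.4-fold lower number from compound 1 to compound 2 (0.15 log units; within the scatter) stayed within the scatter, compound 4 is expected to show a step of similar size, estimated as a 1.4-fold lower number from compound 3 to compound 4 (0.15 log units; within the scatter). Compound 4 is therefore expected to give about 3000 nM in this assay, with a range from 1500 nM to 6500 nM.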

Compound 4, half-maximal inhibitory concentration: 5780 nM
For compound 4 the middle estimate is 1.9-fold (0.28 log units) below the measured one, and the stated range covers the measured number.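

On the core of compound 3, the change gave a 1.4-fold higher number from compound 3 to compound 4 (0.13 log units; within the scatter) in this assay. Set beside the earlier step on the core of compound 1, this step does not differ from it: the same change on two cores in this assay, a 1.4-fold lower number (0.15 log units; within the scatter) from compound 1 to compound 2 and a 1.4-fold higher number (0.13 log units; within the scatter) from compound 3 to compound 4, 1.9-fold (0.28 log units) apart, within the scatter of two such steps. The change therefore carries from one core to the other without a step beyond the scatter on either, but these two pairs cannot show that it has any real effect on either core, or how it would read on a third.

The compounds shown leave open how other amines on the same saturated chain carbon, such as dimethylamino, piperidin-1-yl or morpholin-4-yl, would read in this assay. They also leave open whether any such amine would give a step beyond the scatter.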